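A few compounds are considered here, and "the series" means these few. Any claim that something is new, unique, unknown or untested is made for them only; others in the source may bear on it.

In a functional assay on HCC827 cells (Homo sapiens) for inhibition, read by MTT assay, with a stated time of 48 h, tested at 10 uM (a higher number here means more inhibition at the concentration tested (going by the name of the read-out), a lower number less inhibition), three compounds built on one shared core have been measured. Compound 1 `CCc1ccc(Nc2cc(NC(=O)Nc3c(Cl)cccc3Cl)ncn2)cc1` gives 58%, compound 3 `O=C(Nc1cc(Nc2ccc(F)c(Cl)c2)ncn1)Nc1c(Cl)cccc1Cl` gives 53.7%, and compound 2 `CCc1cccc(Nc2cc(NC(=O)Nc3cc(OC)cc(OC)c3)ncn2)c1` gives 52.6%. On paper the number for compound 2 is the lowest of the three, but its gap to compound 3 and its gap to compound 1 both lie within the usual scatter, so no real order among these three can be claimed. Among the measured compounds shown here, the only measured step that changes a single place, a number 4.3 percentage points lower from compound 1 to compound 3 (within the scatter), also exchanges the aryl group on a nitrogen on an aromatic ring and stays within the scatter. Compound 4 `COc1cc(NC(=O)Nc2cc(Nc3ccc(C)c(C)c3)ncn2)cc(OC)c1` differs from compound 2 by 3,4-dimethylphenyl in place of 3-ethylphenyl on a nitrogen on an aromatic ring. Because a number 4.3 percentage points lower from compound 1 to compound 3 (within the scatter) describes a comparable exchange at the same kind of place that left the read-out essentially unchanged, no movement beyond the scatter is expected here either. Compound 4 is therefore estimated to give 53%, with a range from 41% to 65%. The expected step is then a number 0.4 percentage points higher from compound 2 to compound 4 (within the scatter), which is within the scatter.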

Compound 4, a percentage reported as inhibition, at one concentration (the size of the read-out at that concentration, not a potency): 45.7%
Estimate against measurement, compound 4: 7.3 percentage points above; the range from low to high includes it.
By their numbers in this assay, from the lowest: compounds 4, 2, 3 and 1 (each within the scatter of the next, the first and the last beyond it).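

In this assay, the exchange of 3-ethylphenyl for 3,4-dimethylphenyl on a nitrogen on an aromatic ring gives a number 6.9 percentage points lower from compound 2 to compound 4 (within the scatter), between two groups that both hold 8 heavy atoms, all carbon. Among the compounds shown here, this adds a second single-place exchange at this position, on a different remainder of the molecule from the one in a number 4.3 percentage points lower from compound 1 to compound 3 (within the scatter), and both steps lie within the scatter. Across these two pairs, the read-out at the one tested concentration therefore does not separate the aryl groups compared on this nitrogen. The compounds shown leave open whether any group here would move the read-out beyond the scatter, such as a phenyl ring carrying a carboxylic acid or a dimethylamino group, or a longer alkyl chain in place of the aryl ring. No measurement at hand offers an explanation for the size of either step.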